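A few compounds are considered here, and "the series" means these few. Any claim that something is new, unique, unknown or untested is made for them only; others in the source may bear on it.

Of the compounds shown here, three with a shared core have been tested in a functional assay on the whole organism (strain Wistar Albino) for inhibition, with Rattus norvegicus as the target, read by paw edema, with a stated time of 4 h, at a dose of 20 mg/kg; on this read-out lower numbers stand for less inhibition and higher numbers for more inhibition at the one dose given (going by the name of the read-out). Compound 1, `COc1ccc(Cl)c(-c2nnc3sc(-c4ccnc(Cl)c4)nn23)c1`, carries a chloro group on its pyridine ring; in this assay compound 1 gives 27.2%. Compound 3, `COc1ccc(Cl)c(-c2nnc3sc(-c4ccnc(F)c4)nn23)c1`, carries fluoro in that place instead, and in this assay compound 3 gives 28.1%. The change fluoro in place of chloro on an aromatic carbon thus made a step of a number 0.9 percentage points higher from compound 1 to compound 3 (within the scatter), a difference too small to tell apart from repeated testing. Compound 2, `Cc1occc1-c1nnc2sc(-c3ccnc(Cl)c3)nn12`, has a different core; how the two cores differ is not broken down here. In this assay compound 2 gives 27.1%, a value that sits alongside those of compound 1 and compound 3 within the scatter.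

Compound 4, `Cc1occc1-c1nnc2sc(-c3ccnc(F)c3)nn12`, has not yet been measured. It differs from compound 2 by fluoro in place of chloro on an aromatic carbon, the same change as between compound 1 and compound 3. Because the earlier step was a number 0.9 percentage points higher from compound 1 to compound 3 (within the scatter), the expected step to compound 4 is a number 0.9 percentage points higher from compound 2 to compound 4 (within the scatter). For compound 4 the estimate in this assay is 28%, expected to lie between 20% and 36%.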

Compound 4, a percentage reported as inhibition, in the whole organism at one dose (the size of the read-out at that dose, not a potency): 24.4%
For compound 4 the middle estimate is 3.6 percentage points above the measured one, within the range that was stated.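

On the core of compound 2, fluoro in place of chloro gives a number 2.7 percentage points lower from compound 2 to compound 4 (within the scatter), so on this core, too, the change cannot be told apart from repeated testing. Set side by side in this assay, the steps on the two cores do not differ by more than the scatter allows: the same change on two cores in this assay, a number 0.9 percentage points higher (within the scatter) from compound 1 to compound 3 and a number 2.7 percentage points lower (within the scatter) from compound 2 to compound 4, 3.6 percentage points apart, within the scatter of two such steps

This shows that going from 2-chloropyridin-4-yl to 2-fluoropyridin-4-yl left the read-out within the scatter on both cores, but it does not show that the change has no effect or that the two cores respond identically, as a small effect in either direction could still lie hidden in the scatter.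

The compounds shown leave open whether a different group in that place, such as an amine or a carboxylic acid, would shift the inhibition beyond the scatter. Also open is how these compounds would compare at other doses, as only one dose is shown.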